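This account rests on a few compounds, and the source may have more. Where it says the series, first, only, none or still open, it means among the compounds named here.

Series values in a functional assay on A2780 cells (Homo sapiens) for antiproliferative activity, read by resazurin assay, with a stated time of 72 h; on this read-out higher numbers stand for weaker inhibition and lower numbers for stronger inhibition:
- compound 1 `CN(Cc1ccccc1)C(=O)c1cc2c(Cc3cccc(Cl)c3)n[nH]c2cc1O` gives 410 nM
- compound 2 `CN(Cc1ccccc1Br)C(=O)c1cc2c(Cc3cccc(Cl)c3)n[nH]c2cc1O` gives 130 nM
- compound 3 `CN(Cc1ccc(F)cc1)C(=O)c1cc2c(Cc3cccc(Cl)c3)n[nH]c2cc1O` gives 410 nM

Going by the values given here, compound 3 sits level with compound 1 at the higher end of these three numbers, and the only lower number is the one for compound 2. That gap is a 3.2-fold higher number from compound 2 to compound 3 (0.50 log units; beyond the scatter).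

The next analogue is compound 4 `COc1ccc(CN(C)C(=O)c2cc3c(Cc4cccc(Cl)c4)n[nH]c3cc2O)cc1`, with methoxy in place of fluoro on an aromatic carbon, para to a large group: methoxy in place of fluoro on an aromatic carbon.

Among the compounds with values here, two measured steps bear on this change. Fluoro in place of hydrogen gave no change at the digits printed from compound 1 to compound 3 (within the scatter), so that change at the same ring carbon left the read-out in this assay unmoved. The one clear shift in the series is a 3.2-fold lower number from compound 1 to compound 2 (0.50 log units; beyond the scatter), but it comes from a bromo on the 2-bromophenyl, not from a group at the carbon that changes here. Within the data shown here, no measured compound carries methoxy, so the evidence for this swap is indirect and the range stays wide.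

No shift beyond the scatter is expected, and the expected step is a 1.1-fold lower number from compound 3 to compound 4 (0.06 log units; within the scatter). The estimate for compound 4 is 360 nM, with an expected range of 150 nM to 850 nM.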

Compound 4, half-maximal inhibitory concentration: 390 nM
Beside the measured number, compound 4's estimate is 1.1-fold (0.03 log units) below it; the range from low to high includes it.
By their numbers in this assay, from the lowest: compound 2; then compounds 4, 1 and 3 (each within the scatter of the next).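

In this assay, replacing fluoro with methoxy on the aromatic carbon para to a large group gives a 1.1-fold lower number from compound 3 to compound 4 (0.02 log units; within the scatter), and the same position with methoxy in place of hydrogen gives a 1.1-fold lower number from compound 1 to compound 4 (0.02 log units; within the scatter). Hydrogen, fluoro and methoxy therefore all read alike at this carbon in the three compounds shown, so the read-out stays flat here even when the entering group has two heavy atoms and a hydrogen-bond acceptor, which fluoro lacks. The separation from the 2-bromophenyl analogue also persists, with a 3.0-fold higher number from compound 2 to compound 4 (0.48 log units; beyond the scatter), and no supporting measurement is available to explain the flat response at this carbon or the separation of compound 2.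

The compounds shown leave open whether a group of a different kind on this carbon, such as an amine or a carboxylic acid, would shift the number beyond the scatter. They also leave open whether the step seen with compound 2 belongs to bromo itself or to where it sits, which bromo on the carbon para to a large group would help separate.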